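The source may report more compounds than this note shows. Statements on the series, on what has been measured and on what is new or still open speak of the compounds shown alone.

Going by the values given here, compound 3 `CS(=O)(=O)c1ccc(-c2cnc3[nH]cc(-c4nnc(-c5ccc(Cl)cc5)o4)c(=O)c3c2)cc1` gives 1.64% in a functional assay on HeLa cells (Homo sapiens) for inhibition, read by MTT assay, with a stated time of 24 h, tested at 10 uM (a higher number here means more inhibition of growth at the concentration tested, a lower number less inhibition of growth), the lowest of the three numbers measured so far. Compound 1 `CS(=O)(=O)c1ccc(-c2cnc3[nH]cc(-c4nnc(-c5ccc(F)cc5)o4)c(=O)c3c2)cc1` gives 15.7% in this assay, and compound 2 `CS(=O)(=O)c1ccc(-c2cnc3[nH]cc(-c4nnc(-c5ccccc5)o4)c(=O)c3c2)cc1` gives 17.5%. Among the compounds with values here, the steps of a number 14.1 percentage points lower from compound 1 to compound 3 (beyond the scatter) and a number 15.9 percentage points lower from compound 2 to compound 3 (beyond the scatter) both lie beyond the scatter, whereas the step of a number 1.8 percentage points higher from compound 1 to compound 2 (within the scatter) lies within it, so the only steps on record concern the exchange of fluoro, hydrogen and chloro at one aromatic carbon.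

Compound 4 `N#Cc1ccc(-c2cnc3[nH]cc(-c4nnc(-c5ccc(Cl)cc5)o4)c(=O)c3c2)cc1` has not yet been measured in this assay. It differs from compound 3 by cyano in place of methylsulfonyl on an aromatic carbon. None of the three measured steps touches this part of the structure; all of them vary the halogen on the other side of the molecule, and the methylsulfonyl group is shared by compounds 1, 2 and 3 alike. Within the data shown here, there is therefore no measured step from which the size or direction of this change can be read off. With compound 3 as the starting point and no guide beyond it, the step of a number 4.4 percentage points higher from compound 3 to compound 4 (within the scatter) is expected to be small, with no direction favoured. Compound 4 is accordingly expected to give about 6% in this assay, with a range from -8% to 24%.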

Compound 4, percent growth inhibition at one concentration: 13.7%
Compound 4: middle estimate off by 7.7 percentage points, on the low side; low and high end bracket the measured number.
By their numbers in this assay, from the lowest: compound 3; then compounds 4, 1 and 2 (each within the scatter of the next).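

The exchange of 4-(methylsulfonyl)phenyl for 4-cyanophenyl gives a number 12.1 percentage points higher from compound 3 to compound 4 (beyond the scatter) in this assay, so the aromatic carbon carrying this group, para to a large group, is a second place in the series where a single change moves the number beyond the scatter. The earlier steps shown here showed such a shift only for chloro at the site that carries fluoro, hydrogen or chloro, and those steps ran downward, whereas this one runs upward, so the methylsulfonyl group is not required for the measured growth inhibition at the concentration tested when chloro is present. The data shown give no cause for this step, and the smaller group with fewer hydrogen-bond acceptors cannot be credited with it on this single pair.

Going by these compounds alone, only one matched pair carries this exchange, so it remains open whether cyano gives a step of similar size and direction with fluoro or hydrogen in place of chloro. Also open, going by these compounds, is how an amine, a carboxylic acid or a simple methyl at this aromatic carbon would compare with cyano and methylsulfonyl in this assay on the same chloro-bearing scaffold.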